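Three measured analogues and one compound still to be tested

The source may hold more compounds than are shown below. What is called first, only, known or untested is meant among the compounds shown, and "the series" means these compounds.

Three compounds have so far been measured in an assay on HEK293 cells for activation of Kir3.1/Kir3.2 (Homo sapiens), read by thallium flux; a lower number here means a smaller maximal response, a higher number a larger maximal response:

Compound 1, `Cc1cc(NC(=O)Cn2nnc(-c3cccc(Cl)c3)n2)n(C2CCCCC2)n1`: 89%
Compound 2, `Cc1cc(NC(=O)Cn2nnc(-c3ccc(Cl)c(Cl)c3)n2)n(C2CCCCC2)n1`: 84%
Compound 3, `Cc1cc(NC(=O)Cn2nnc(-c3ccc(F)c(F)c3)n2)n(C2CCCCC2)n1`: 93%

Compound 3 holds the highest of the three numbers, but the gaps to its neighbours are small: the nearest is compound 1, with a number 4 percentage points higher from compound 1 to compound 3 (within the scatter), and the furthest is compound 2, with a number 9 percentage points higher from compound 2 to compound 3 (within the scatter). The remaining step, a number 5 percentage points lower from compound 1 to compound 2 (within the scatter), is likewise within the scatter, so the three compounds cannot be told apart on these numbers.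

Compound 4, `Cc1ccc(-c2nnn(CC(=O)Nc3cc(C)nn3C3CCCCC3)n2)cc1`, has not yet been measured. It differs from compound 3 in one place: 4-methylphenyl in place of 3,4-difluorophenyl on an aromatic carbon.

The measured steps that bear on this change are the two that also alter the group on the same aromatic carbon, a number 4 percentage points higher from compound 1 to compound 3 (within the scatter) and a number 9 percentage points higher from compound 2 to compound 3 (within the scatter), together with a number 5 percentage points lower from compound 1 to compound 2 (within the scatter). All three exchange one halogen pattern for another and none leaves the scatter. Among the measured compounds shown here, no measured step involves a 4-methylphenyl group, so the expectation rests on the general steadiness of the numbers. Compound 4 is therefore expected to move by a number 7 percentage points lower from compound 3 to compound 4 (within the scatter), a step not beyond the scatter. The estimate for compound 4 in this assay is 86%, with a range from 66% to 100%.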

Compound 4, largest response reached (Emax), in percent of the reference or control that the assay uses: 86%
Estimate against measurement, compound 4: no gap at the digits printed; the measured number falls inside the stated range.
By their numbers in this assay, from the lowest: compounds 2, 4, 1 and 3 (each within the scatter of the next).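

Compound 4 shows that in this assay the aromatic group on this carbon of the five-membered ring need not carry halogen for the largest response to stay level with the others: the exchange for 4-methylphenyl gives steps (a number 7 percentage points lower from compound 3 to compound 4 (within the scatter); a number 2 percentage points higher from compound 2 to compound 4 (within the scatter); a number 3 percentage points lower from compound 1 to compound 4 (within the scatter)) that are all within the scatter. Across these four compounds, therefore, the chloro, fluoro and methyl patterns on the phenyl group cannot be told apart on this read-out, and none of the four goes against that reading. No supporting data bear on why the response holds across this change.

The compounds shown leave open whether a different kind of group on this phenyl ring, such as an amine, a carboxylic acid or a methoxy group, would hold the response in the same range, and whether a saturated ring such as cyclohexyl could take the place of the phenyl ring itself. They also leave open how the concentration needed for this response shifts with these groups, since only the largest response is given here.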